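Swapping a Fluoropyridine for Dimethylphenyl on the Sulfonamide

A few compounds are considered here, and "the series" means these few. Any claim that something is new, unique, unknown or untested is made for them only; others in the source may bear on it.

Compound 1 `Cc1cc(S(=O)(=O)N2[C@H](CO)CC[C@@H]2c2ccc(F)cc2)cc(C)c1F`: 63 nM
Compound 2 `O=S(=O)(c1ccc(F)cn1)N1[C@H](CO)CC[C@@H]1c1ccc(F)cc1`: > 20000 nM

In an assay on isolated protein for inhibition of transient receptor potential cation channel subfamily A member 1 (Homo sapiens) (a lower number here means a stronger inhibitor, a higher number a weaker inhibitor), compound 1 gives 63 nM. Compound 2 returns only a limit of the assay, > 20000 nM (the limit of > 20000 nM in this assay, at which 1 of the 2 values shown sits), so it stands at the weak end of the two numbers shown, without an exact value of its own. Compound 3 `Cc1cc(C)cc(S(=O)(=O)N2[C@H](CO)CC[C@@H]2c2ccc(F)cc2)c1` has not yet been measured. It differs from compound 2 by 3,5-dimethylphenyl in place of 5-fluoropyridin-2-yl on a sulfonyl sulfur. Going by the values given here, no step between measured compounds covers this change, so the expectation rests on compound 1, whose structure shows a related carbon-only ring on the sulfonyl sulfur and which gives 63 nM in this assay. The step from compound 2 to compound 3 is therefore expected to be large and toward stronger inhibition, an at least 200-fold lower number from compound 2 to compound 3 (2.30 log units; beyond the scatter). Compound 3 is estimated at 100 nM, with a likely range from 30 nM to 400 nM.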

Compound 3, half-maximal inhibitory concentration in the transient receptor potential cation channel subfamily A member 1 assay: 290 nM
For compound 3 the middle estimate is 2.9-fold (0.46 log units) below the measured one; measured number inside the range.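

In the transient receptor potential cation channel subfamily A member 1 assay, 3,5-dimethylphenyl in place of 5-fluoropyridin-2-yl on the sulfonyl sulfur gives an at least 68-fold lower number from compound 2 to compound 3 (1.83 log units; beyond the scatter), and this step is only a bound because the value of compound 2 is a limit: the limit of > 20000 nM in the transient receptor potential cation channel subfamily A member 1 assay, at which 1 of the 3 values shown sits. The same change also moves the reading in a physicochemical assay for lipophilicity, at pH 7.4; a higher number here means a more lipophilic compound, a lower number a more polar compound: the measured distribution coefficient of compound 2, 2, and of compound 3, 3.2, a number 1.20 log units higher (beyond the scatter). In the physicochemical assay compound 2 gives 2 and compound 3 gives 3.2. In the transient receptor potential cation channel subfamily A member 1 assay, hydrogen in place of fluoro on an aromatic carbon gives a 4.6-fold higher number from compound 1 to compound 3 (0.66 log units; beyond the scatter), a modest step against the large one, so compound 3 keeps measurable inhibition without the fluoro.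

The compounds shown leave open whether the ring nitrogen, the two methyl groups or the ring fluoro of compound 2 accounts for its weakness, and whether potency simply follows the distribution coefficient. Plain phenyl or 3,5-dichlorophenyl on the sulfonyl sulfur would bear on both questions.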